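The source may hold more compounds than are shown below. What is called first, only, known or untested is meant among the compounds shown, and "the series" means these compounds.

Measured so far in a functional assay for inhibition, with Homo sapiens as the target; a lower number here means a stronger inhibitor, a higher number a weaker inhibitor:
compound 1, `CC(C)(C)Sc1c(CC(C)(C)C(=O)O)n(Cc2ccc(Cl)cc2)c2ccc(OCc3ccc4cccnc4n3)cc12`, gives 6 nM;
compound 2, `COc1ccc2nc(COc3ccc4c(c3)c(SC(C)(C)C)c(CC(C)(C)C(=O)O)n4Cc3ccc(Cl)cc3)sc2c1`, gives 8 nM;
compound 3, `C[C@H](COc1ccc2c(c1)c(SC(C)(C)C)c(CC(C)(C)C(=O)O)n2Cc1ccc(Cl)cc1)c1ccccn1`, gives 3 nM.

Compound 2 and compound 1 sit within the scatter of each other, as the step of a 1.3-fold higher number from compound 1 to compound 2 (0.12 log units; within the scatter) shows, while the modest step of a 2.7-fold lower number from compound 2 to compound 3 (0.43 log units; beyond the scatter) sets compound 2 apart from compound 3. Compound 4, `CC(C)c1csc(COc2ccc3c(c2)c(SC(C)(C)C)c(CC(C)(C)C(=O)O)n3Cc2ccc(Cl)cc2)n1`, is not yet measured. It differs from compound 2 in one place: 4-isopropyl-1,3-thiazol-2-yl in place of 6-methoxy-1,3-benzothiazol-2-yl on a saturated chain carbon bound to an oxygen on an aromatic ring. All three measured steps swap the ring group on that same carbon, and two of them, a 1.3-fold higher number from compound 1 to compound 2 (0.12 log units; within the scatter) and a 2.0-fold lower number from compound 1 to compound 3 (0.30 log units; within the scatter), stay within the scatter. Such a swap therefore seems to move the number little, and for compound 4 a step of a 1.3-fold lower number from compound 2 to compound 4 (0.12 log units; within the scatter) is expected. The estimate for compound 4 in this assay is 6 nM, within 2 nM to 20 nM.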

Compound 4, half-maximal inhibitory concentration: 3 nM
The estimate for compound 4 lay 2.0-fold (0.30 log units) above the measured number; low and high end bracket the measured number.
By their numbers in this assay, from the lowest: compounds 3, 4, 1 and 2 (each within the scatter of the next, the first and the last beyond it).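

On the saturated chain carbon bound to an oxygen on an aromatic ring, a single five-membered aromatic ring bearing isopropyl does at least as well in this assay as the larger fused group of compound 2 (a 2.7-fold lower number from compound 2 to compound 4 (0.43 log units; beyond the scatter)), a modest step. The new group also stays level with the groups of the other two compounds (no change at the digits printed from compound 3 to compound 4 (within the scatter); a 2.0-fold lower number from compound 1 to compound 4 (0.30 log units; within the scatter)). Nothing measured here explains the step from the fused group. Going by these compounds, whether an amine or a longer chain in place of the isopropyl would keep this number remains open.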